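Notes on the shared core: compound 3 to compound 4

The compounds below may be only part of what the source reports. "The series", "measured", "known", "first", "only" and "open" are said of these compounds alone.

Compound 1, `CCOC(=O)C1=Cc2ccccc2OC1(OCc1cc(-c2ccc(F)cc2F)no1)C(F)(F)F`, carries an ethyl ester. In a functional assay on MCF7 cells (Homo sapiens) for inhibition, read by MTT assay, with a stated time of 24 h (a higher number here means a weaker inhibitor, a lower number a stronger inhibitor), compound 1 gives only a limit, > 150000 nM. Compound 2 is `O=C(O)C1=Cc2ccccc2OC1(OCc1cc(-c2ccc([N+](=O)[O-])cc2)no1)C(F)(F)F`. In this assay compound 2 likewise reaches only the limit, > 150000 nM. Compound 3, `O=C(O)C1=Cc2ccccc2OC1(OCc1cc(-c2ccc(F)cc2F)no1)C(F)(F)F`, the free acid with a 2,4-difluorophenyl group, is also reported in this assay as a limit, > 150000 nM. Both recorded steps are thus unreadable: a step that the two limits leave unreadable from compound 1 to compound 3 and a step that the two limits leave unreadable from compound 2 to compound 3. Compound 3 stands where the whole series stands, at the limit of > 150000 nM in this assay, at which 3 of the 3 values shown sit; no number separates it from compound 1 or compound 2.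

Compound 4 is `O=C(O)C1=Cc2ccccc2OC1(OCc1cc(-c2cccc(C(F)(F)F)c2)no1)C(F)(F)F`. It differs from compound 3 in one place: 3-(trifluoromethyl)phenyl in place of 2,4-difluorophenyl on an aromatic carbon. Among the measured compounds shown here, no measured step speaks directly to this exchange; the two recorded steps are both unreadable, and the aryl variation that one of them covers, 4-nitrophenyl against 2,4-difluorophenyl, left the limit untouched. The expectation is therefore no step beyond the scatter, with the limit most likely returned again. The expected step is a step that the limit leaves unreadable from compound 3 to compound 4. Compound 4 is expected at 200000 nM, within a range from 100000 nM to 500000 nM.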

Compound 4, half-maximal inhibitory concentration: > 150000 nM
Compound 4: a limit, no number; the forecaster's own chance of this, stated with the estimate: 85%; the middle value does not contradict the limit.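

No new step can be read: compound 4, like compound 2 and compound 3, gives only a limit in this assay, so neither comparison has a size. What the compounds shown leave open is whether any change to the shared core or its aryl group yields a number in this assay. The series stands as one group: the limit of > 150000 nM in this assay, at which 4 of the 4 values shown sit.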